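Ethylsulfanyl for ethoxy on compound 1

This account rests on a few compounds, and the source may have more. Where it says the series, first, only, none or still open, it means among the compounds named here.

Among the compounds with values here, in a functional assay on HT-29 cells (Homo sapiens) for inhibition, read by sulforhodamine B assay, with a stated time of 72 h (a higher number here means a weaker inhibitor, a lower number a stronger inhibitor), compound 1 (`CCOc1ccc(C2C(C3CC3)C(=O)N2c2cc(OC)c(OC)c(OC)c2)cc1`) gives 63 nM as its reading, and compound 2 (`C=CC1C(=O)N(c2cc(OC)c(OC)c(OC)c2)C1c1ccc(OCC)cc1`) gives 97 nM as the only other number available. Within the data shown here, the sole measured step is a 1.5-fold higher number from compound 1 to compound 2 (0.19 log units; within the scatter) and it puts vinyl in place of cyclopropyl on a saturated ring carbon. Compound 3 (`CCSc1ccc(C2C(C3CC3)C(=O)N2c2cc(OC)c(OC)c(OC)c2)cc1`) instead carries ethylsulfanyl in place of ethoxy on an aromatic carbon. Among the measured compounds shown here, no measured step touches that aromatic carbon, so the data offer no direct guide. The expected outcome is a 1.3-fold higher number from compound 1 to compound 3 (0.13 log units; within the scatter) and thus nothing beyond the scatter. Compound 3 is estimated at 85 nM (range 28 nM to 260 nM).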

Compound 3, half-maximal inhibitory concentration: 1560 nM
The estimate for compound 3 lay 18-fold (1.26 log units) below the measured number; the whole stated range lies below it.
By their numbers in this assay, from the lowest: compounds 1 and 2 (each within the scatter of the next); then compound 3.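

This position is far less forgiving than the earlier pair suggested. Exchanging only the oxygen of the ethoxy group for sulfur, on an aromatic carbon para to a large group, gives a 25-fold higher number from compound 1 to compound 3 (1.39 log units; beyond the scatter) in this assay, so a change of a single atom here costs much of the activity. Nothing available explains this sensitivity.

The compounds shown leave open whether the loss is specific to ethylsulfanyl or would also follow other groups on this carbon, such as a longer propoxy chain or an ethylamino group.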